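One Added Methoxy on Compound 3

This account rests on a few compounds, and the source may have more. Where it says the series, first, only, none or still open, it means among the compounds named here.

Compound 3 (`COc1ccccc1/C=C1\CCC/C(=C\c2ccc(OC)c(OC)c2)C1=O`) gives 7800 nM in a functional assay on SW-620 cells (Homo sapiens) for cytotoxicity, read by MTT assay, with a stated time of 72 h (a higher number here means a weaker inhibitor, a lower number a stronger inhibitor), and lies within the scatter of compound 1 (`COc1ccc(/C=C2\CCC/C(=C\c3ccccc3Cl)C2=O)cc1OC`) with 7100 nM and of compound 2 (`COc1ccc(/C=C2\CCC/C(=C\c3ccc(Cl)cc3)C2=O)cc1OC`) with 5900 nM as its measured neighbours. Compound 4 (`COc1ccc(/C=C2\CCC/C(=C\c3ccc(OC)c(OC)c3)C2=O)c(OC)c1`) carries one change from compound 3: methoxy in place of hydrogen on an aromatic carbon. Going by the values given here, no measured step adds a group in this way. The closest guides are swaps of ring groups, a 1.1-fold higher number from compound 1 to compound 3 (0.04 log units; within the scatter) and a 1.3-fold higher number from compound 2 to compound 3 (0.12 log units; within the scatter) and both stay within the scatter. The expected size is a 1.2-fold lower number from compound 3 to compound 4 (0.08 log units; within the scatter) and no shift beyond the scatter is anticipated. In this assay compound 4 is expected at 6500 nM with an estimated range from 3000 nM to 14000 nM as the likely span.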

Compound 4, half-maximal inhibitory concentration: > 20000 nM
Compound 4: a limit, no number; the forecaster's own chance of this, stated with the estimate: 3%; middle value at least 3.0-fold (0.48 log units) from the limit.
By their numbers in this assay, from the lowest: compounds 2, 1 and 3 (each within the scatter of the next). At a limit, above all of these: compound 4.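

Adding methoxy on an aromatic carbon, meta to a methoxy group and para to a large group, gives an at least 2.5-fold higher number from compound 3 to compound 4 (0.40 log units; beyond the scatter), the only step shown that lies beyond the scatter in this assay. Going by these compounds alone, the ring-group swaps among compounds 1, 2 and 3 all stayed within the scatter, so this carbon is the first place where one change clearly weakens a compound. Going by these compounds, compound 4 gives > 20000 nM, which is a limit and not a number, so the full size of the step stays unknown.

On these data alone, whether the loss belongs to methoxy alone or would follow any group at this carbon remains open. A hydroxy group or an amine in the same place would help separate the two.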